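The compounds below may be only part of what the source reports. "The series", "measured", "known", "first", "only" and "open" are said of these compounds alone.

Three compounds that differ only in the group on an oxygen and in where that group sits have been tested in a functional assay on M21 cells (Homo sapiens) for inhibition, read by sulforhodamine B assay, with a stated time of 48 h; a lower number here means a stronger inhibitor of growth, a higher number a weaker inhibitor of growth. Compound 1 `c1cc(OC2CCCC2)ccc1NC1=NCCO1` gives 21100 nM, compound 3 `c1ccc(Oc2ccc(NC3=NCCO3)cc2)cc1` gives 3100 nM, and compound 2 `c1cc(NC2=NCCO2)cc(OC2CCCC2)c1` gives 76900 nM. Compound 2 therefore has the highest number of the three. It is the weakest inhibitor of growth in this small set, and the gaps to both other compounds lie beyond the usual scatter.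

Compound 4 `c1ccc(Oc2cccc(NC3=NCCO3)c2)cc1` has not yet been measured. It comes from compound 2 through a single structural change: phenyl in place of cyclopentyl on an oxygen on an aromatic ring. In words, this is phenyl in place of cyclopentyl on an oxygen on an aromatic ring.

For the measured compounds named here, only one measured step shows this same exchange: a 6.8-fold lower number from compound 1 to compound 3 (0.83 log units; beyond the scatter). That modest step lies beyond the scatter and points towards stronger growth inhibition. It is a single example from another pair of compounds, so it may not carry over in full. A step of similar size and the same direction is still expected in this assay. The expected step is a 7.0-fold lower number from compound 2 to compound 4 (0.84 log units; beyond the scatter). For compound 4 the estimated value is 11000 nM, with an expected range from 4000 nM to 30000 nM.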

Compound 4, concentration for 50% growth inhibition: 9600 nM
For compound 4 the middle estimate is 1.1-fold (0.06 log units) above the measured one; measured number inside the range.
By their numbers in this assay, from the lowest: compound 3; then compound 4; then compound 1; then compound 2.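

Phenyl in place of cyclopentyl on an oxygen on an aromatic ring now has a second example, this time on the core of compound 2, and in this assay the exchange gives an 8.0-fold lower number from compound 2 to compound 4 (0.90 log units; beyond the scatter). Before this result, the change had been seen on a single pair of compounds, so its effect could have been specific to the core of compound 1. The new step shows that phenyl goes with stronger growth inhibition than cyclopentyl on both cores, with steps of closely matching size, so in this small set the effect of the exchange does not depend on which of the two cores carries it: the same change on two cores in this assay, a 6.8-fold lower number (0.83 log units; beyond the scatter) from compound 1 to compound 3 and an 8.0-fold lower number (0.90 log units; beyond the scatter) from compound 2 to compound 4, 1.2-fold (0.07 log units) apart, within the scatter of two such steps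

The four compounds compare only cyclopentyl and phenyl on this oxygen, so they leave open how a different group there, such as a longer alkyl chain, a methyl group or a phenyl ring carrying a chlorine atom, would behave in this assay. They also do not show why phenyl gives the lower number, or whether the same exchange would give a similar step on any core beyond these two.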